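Adding 3-methoxyphenyl to a weak antiproliferative compound

This account rests on a few compounds, and the source may have more. Where it says the series, first, only, none or still open, it means among the compounds named here.

Measured so far in a functional assay on MDA-MB-231 cells (Homo sapiens) for antiproliferative activity, read by MTT assay, with a stated time of 72 h; on this read-out lower numbers stand for stronger inhibition and higher numbers for weaker inhibition
- compound 1 `COc1cc(OC)cc(-c2cccc(NC(=O)CCc3cccc4c3B(O)OC4)c2)c1` gives 40 nM
- compound 2 `O=C(CCc1cccc2c1C(O)OC2)Nc1ccccc1` gives 12000 nM

In this assay compound 2 has the higher of the two numbers, so it is the weaker inhibitor, and its gap to compound 1 lies beyond the usual scatter. Compound 3 `COc1cccc(-c2cccc(NC(=O)CCc3cccc4c3C(O)OC4)c2)c1` has not been measured yet. It is compound 2 with 3-methoxyphenyl in place of hydrogen on an aromatic carbon, meta to a large group 3-methoxyphenyl in place of hydrogen on an aromatic carbon and nothing else changed. Going by the values given here, no measured pair differs in one place only, so this kind of change has not been seen directly. Among the compounds with values here, the one hint is compound 1 at 40 nM which also carries a further aromatic ring of carbon only but differs from compound 2 in other ways too. The expected change is a 6.0-fold lower number from compound 2 to compound 3 (0.78 log units; beyond the scatter) toward stronger inhibition, beyond the scatter but well short of the whole gap. Compound 3 is estimated at 2000 nM with a likely range of 300 nM to 12000 nM in this assay when it is measured.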

Compound 3, half-maximal inhibitory concentration: 52000 nM
Beside the measured number, compound 3's estimate is 26-fold (1.41 log units) below it; measured number above the stated range.
By their numbers in this assay, from the lowest: compound 1; then compound 2; then compound 3.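

In this assay, going by these compounds alone, putting 3-methoxyphenyl in place of hydrogen on this aromatic carbon gives a 4.3-fold higher number from compound 2 to compound 3 (0.64 log units; beyond the scatter), the first direct reading of this change. On the core of compound 2, then, a further aromatic ring at this position moves the number toward weaker inhibition, so adding this ring here does not by itself bring stronger inhibition. No measurement at hand gives a reason for this rise.

Within the data shown here, compound 3 and compound 1 differ in more than one place, so no step between them can be read, and which of those differences goes with the value of compound 1 at 40 nM stays open. Also open, on these data alone, is how the number would move with an amine or a carboxylic acid in place of 3-methoxyphenyl at this position.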